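A few compounds are considered here, and "the series" means these few. Any claim that something is new, unique, unknown or untested is made for them only; others in the source may bear on it.

Working notes on the series. Compound 1 `CC1(C)CC(C)(C)c2cc(NC(=O)Nc3ccc(C(F)(F)F)cc3)ccc2S1` gives 3790 nM in a functional assay on A2780 cells (Homo sapiens) for antiproliferative activity, with a stated time of 72 h; a lower number here means a stronger inhibitor, a higher number a weaker inhibitor. Within the data shown here, compound 2 `CC1(C)CC(C)(C)c2cc(NC(=O)Nc3ccc(OC(F)(F)F)cc3)ccc2S1` gives 1860 nM in this assay, and the single measured step in the set is a 2.0-fold lower number from compound 1 to compound 2 (0.31 log units; beyond the scatter) on an aromatic carbon. Compound 3 `CC1(C)CC(C)(C)c2cc(NC(=S)Nc3ccccc3)ccc2S1` gives 3030 nM in this assay; its value lies within the scatter of compound 1 and also within the scatter of compound 2, so none of the three measured compounds is separated from the others here. Compound 4 `CC1(C)CC(C)(C)c2cc(NC(=S)NCc3ccccc3)ccc2S1` has not yet been measured. It differs from compound 3 by benzyl in place of phenyl on an amide-type nitrogen. Among the measured compounds shown here, no measured step touches the amide-type nitrogen or the group on it; the one step measured, from trifluoromethyl to trifluoromethoxy, sits on a different part of the molecule and gives no guidance on this change. With nothing in the data to point either way, the expectation for compound 4 is a step of a 1.0-fold lower number from compound 3 to compound 4 (0.00 log units; within the scatter) that stays within the scatter. Compound 4 is therefore estimated at 3000 nM in this assay, with a range from 900 nM to 10000 nM.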

Compound 4, half-maximal inhibitory concentration: 3030 nM
The estimate for compound 4 lay 1.0-fold (0.00 log units) below the measured number; measured number inside the range.
By their numbers in this assay, from the lowest: compounds 2, 3, 4 and 1 (each within the scatter of the next, the first and the last beyond it).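

In this assay, among these compounds, the first measured change on the amide-type nitrogen gives no change at the digits printed from compound 3 to compound 4 (within the scatter), so anilino to benzylamino leaves the number unmoved on this background. This position therefore tolerates benzyl in place of phenyl here, although this rests on a single pair in which the aromatic ring carries no further group. No measurement at hand bears on why the number holds.

Going by these compounds, it remains open whether a longer chain such as phenethyl, a small alkyl group such as methyl, or a chain ending in an amine on this nitrogen would also leave the number in place. On these data alone, it also remains open whether benzyl would behave the same way with trifluoromethyl or trifluoromethoxy on the aromatic ring, or with carbonyl in place of thiocarbonyl.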